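This account rests on a few compounds, and the source may have more. Where it says the series, first, only, none or still open, it means among the compounds named here.

Measured so far in an assay on cells for agonist activity at probable G-protein coupled receptor 34 (Mus musculus), with a stated time of 1 h; on this read-out lower numbers stand for smaller maximal responses and higher numbers for larger maximal responses:
compound 1 `CCCCCCCCCCCOc1ccccc1CCC(=O)OCCCOP(=O)(O)OC[C@H](N)C(=O)O`: 14.6%
compound 2 `N[C@@H](COP(=O)(O)OCCCOC(=O)CCc1ccccc1OCCCCOc1ccccc1)C(=O)O`: 6.1%
compound 3 `N[C@@H](COP(=O)(O)OCCCOC(=O)CCc1ccccc1OCc1cccc(Oc2ccccc2)c1)C(=O)O`: 19.4%

Compound 3 stands highest of these three numbers; its gap to compound 1 lies within the scatter, its gap to compound 2 beyond it. Compound 4 `Cc1cccc(Oc2cccc(COc3ccccc3CCC(=O)OCCCOP(=O)(O)OC[C@H](N)C(=O)O)c2)c1` differs from compound 3 by one change: methyl in place of hydrogen on an aromatic carbon. Among the measured compounds shown here, no measured pair shows a methyl entering an aromatic ring, so none bears directly on this step. For the measured compounds named here, the only measured step, a number 8.5 percentage points lower from compound 1 to compound 2 (within the scatter), was itself within the scatter and concerns a different part of the molecule. The step of a number 0.6 percentage points higher from compound 3 to compound 4 (within the scatter) is therefore expected to stay within the scatter, with no clear direction. Compound 4 is expected to give about 20% in this assay, in the range 8% to 34%.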

Compound 4, largest response reached (Emax), in percent of the reference or control that the assay uses: 21.3%
Compound 4: the middle estimate sits 1.3 percentage points below what was measured, and the stated range covers the measured number.
By their numbers in this assay, from the lowest: compounds 2, 1, 3 and 4 (each within the scatter of the next, the first and the last beyond it).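

In this assay, phenoxy to 3-methylphenoxy gives a number 1.9 percentage points higher from compound 3 to compound 4 (within the scatter), so a methyl on this aromatic carbon leaves the maximal response without a readable change. Unlike the earlier step, which concerned a saturated chain carbon, this one tests a change on the aromatic ring itself. Nothing available accounts for this result.

From the compounds shown here alone, whether an amine, a carboxylic acid or a longer chain on this same carbon would move the response beyond the scatter remains open. So does the effect of a methyl on the ring's other carbons.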